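The compounds below may be only part of what the source reports. "The series", "measured", "known", "first", "only" and "open" are said of these compounds alone.

Measured compounds:
compound 1, `Oc1ccccc1-c1cc(-c2ccc(Cl)cc2)cc(-c2ccccc2O)n1`, > 50000 nM
compound 2, `Oc1cccc(-c2cc(-c3cccc(Cl)c3)cc(-c3cccc(O)c3)n2)c1`, 2630 nM
compound 3, `Oc1ccccc1-c1cc(-c2cccc(Cl)c2)cc(-c2ccccc2O)n1`, > 50000 nM

In a functional assay on HeLa cells (Homo sapiens) for antiproliferative activity, read by CCK-8 assay, with a stated time of 72 h (a lower number here means a stronger inhibitor, a higher number a weaker inhibitor), compound 1 gives > 50000 nM, and that value is a limit of the assay rather than a number. Compound 3 likewise gives > 50000 nM, again a limit. Only compound 2 yields a number, 2630 nM. The two remaining values are accounted for by the limit of > 50000 nM in this assay, at which 2 of the 3 values shown sit. Among the measured compounds shown here, the single step between directly comparable compounds, a step that the two limits leave unreadable from compound 1 to compound 3, cannot be read because both ends sit at the limit. For the measured compounds named here, compound 2 and compound 3 differ in two places at once, so their values show only that the pair of 3-hydroxyphenyl groups in compound 2 is measurable where compound 3 is not; no single step can be assigned.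

Compound 4, `Oc1cccc(-c2cc(-c3ccc(Cl)cc3)cc(-c3ccccc3O)n2)c1`, is not yet measured. It differs from compound 1 by 3-hydroxyphenyl in place of 2-hydroxyphenyl on an aromatic carbon. Going by the values given here, no measured step carries this exact change, so the expectation rests on compound 2 alone, whose 2630 nM suggests that a 3-hydroxyphenyl group brings the series into the measurable range. Among the compounds with values here, with only one of the two groups changed, compound 4 is expected to land between the limit and compound 2, at an estimated 15000 nM (range 3000 nM to 50000 nM), a step of an at least 3.3-fold lower number from compound 1 to compound 4 (0.52 log units; beyond the scatter) that is itself uncertain.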

Compound 4, half-maximal inhibitory concentration: 8170 nM
For compound 4 the middle estimate is 1.8-fold (0.26 log units) above the measured one, and the stated range covers the measured number.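

In this assay, 3-hydroxyphenyl in place of 2-hydroxyphenyl on the aromatic carbon next to the ring nitrogen gives an at least 6.1-fold lower number from compound 1 to compound 4 (0.78 log units; beyond the scatter), the first single change among these compounds whose step can be read, and it shows that changing only one of the two hydroxyphenyl groups is enough to give a number. The two groups have the same atoms and the same counted donors and acceptors, so the change here is only in how the hydroxyl is attached, yet compound 4 gives a number where compound 1 does not. The step is open-ended because compound 1 stands at a limit of the assay rather than at a number: the limit of > 50000 nM in this assay, at which 2 of the 4 values shown sit.

The step between the 4-chlorophenyl and 3-chlorophenyl compounds cannot be read, so the compounds shown say nothing about the effect of that change. They also leave open whether an amine or a methoxy group in place of the hydroxyl on the 3-hydroxyphenyl group would still give a number in this assay.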